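Cyano addition on the diaryl ether of compound 1

A few compounds are considered here, and "the series" means these few. Any claim that something is new, unique, unknown or untested is made for them only; others in the source may bear on it.

Measured compounds:
- compound 1, `Cc1cccc(C)c1Oc1ccc([N+](=O)[O-])c(Nc2ccc(C#N)cc2)c1`, an ADME assay on H9 cells (Homo sapiens) for cytotoxicity, read by XTT assay, with a stated time of 6 days; a higher number here means that more compound is tolerated, a lower number that less compound is tolerated: 69600 nM
- compound 2, `Cc1cc(C)c(Oc2cc(Nc3ccc(C#N)cc3)c(N)cc2[N+](=O)[O-])c(C)c1`, this assay: 32200 nM
- compound 3, `COc1ccc(Nc2cc(Oc3c(C)cc(Br)cc3C)c([N+](=O)[O-])cc2[N+](=O)[O-])cc1`, this assay: 51200 nM

Compound 1 shows the highest of the three numbers in this assay. Its gap to compound 3 is within the usual scatter, so the two cannot be ordered; only compound 2 lies beyond the scatter, at a lower number than compound 1.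

Compound 4, `Cc1cc(C#N)cc(C)c1Oc1ccc([N+](=O)[O-])c(Nc2ccc(C#N)cc2)c1`, has not yet been measured. It differs from compound 1 in one place: cyano in place of hydrogen on an aromatic carbon. For the measured compounds named here, no pair of measured compounds in this set differs by exactly this change, so no measured step can be used as a template.

With nothing in the measured pairs pointing one way, the expected step from compound 1 to compound 4, a 1.2-fold lower number from compound 1 to compound 4 (0.06 log units; within the scatter), is small and not beyond the scatter, in either direction. Compound 4 is accordingly estimated at 60000 nM in this assay, with a plausible range from 25000 nM to 140000 nM.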

Compound 4, half-maximal cytotoxic concentration: > 65100 nM
Compound 4: a limit, no number; the forecaster's own chance of this, stated with the estimate: 15%; at least 1.0-fold (0.03 log units) between middle value and limit.
By their numbers in this assay, from the lowest: compounds 2, 3 and 1 (each within the scatter of the next, the first and the last beyond it).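

In this assay compound 4 gives > 65100 nM, a limit of the assay and not a number. The step from compound 1 to compound 4 cannot be read. The compounds shown leave open whether cyano in place of hydrogen on an aromatic carbon shifts the number in this assay at all, and in which direction.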